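The source may hold more compounds than are shown below. What is called first, only, known or untested is meant among the compounds shown, and "the series" means these compounds.

Compound 1 `CC(C)=CCc1cc(C(=O)Nc2cc3ccc(OCCCN4CCCCC4)c(C)c3oc2=O)ccc1O` reaches only a limit in a functional assay on MCF7 cells (Homo sapiens) for antiproliferative activity (on this read-out lower numbers stand for stronger inhibition and higher numbers for weaker inhibition), giving > 50000 nM. Compound 1 thus stands at the limit of > 50000 nM in this assay, at which 1 of the 2 values shown sits. Compound 2 `CC(C)=CCc1cc(C(=O)Nc2cc3ccc(OCCCNC4CCCCC4)c(C)c3oc2=O)ccc1O` gives 1070 nM, and the step of an at least 46-fold lower number from compound 1 to compound 2 (1.66 log units; beyond the scatter) is the only measured one that bears on the change at hand. Compound 3 `CC(C)=CCc1cc(C(=O)Nc2cc3ccc(OCCCN(C)C4CCCCC4)c(C)c3oc2=O)ccc1O` differs from compound 1 by cyclohexyl(methyl)amino in place of piperidin-1-yl on a saturated chain carbon, three bonds along the chain from an oxygen on an aromatic ring. Because the step of an at least 46-fold lower number from compound 1 to compound 2 (1.66 log units; beyond the scatter) also removed piperidin-1-yl at the same place, compound 3 is expected to show an at least 8.3-fold lower number from compound 1 to compound 3 (0.92 log units; beyond the scatter). Compound 3 is estimated at 6000 nM, within a range from 1000 nM to 50000 nM.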

Compound 3, half-maximal inhibitory concentration: 1080 nM
Compound 3: the middle estimate sits 5.6-fold (0.74 log units) above what was measured, within the range that was stated.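

In this assay, methyl in place of hydrogen on the amine nitrogen gives a 1.0-fold higher number from compound 2 to compound 3 (0.00 log units; within the scatter), so the hydrogen on that nitrogen is not required for this read-out. Cyclohexyl(methyl)amino, which like piperidin-1-yl has no hydrogen-bond donor, still gives an at least 46-fold lower number from compound 1 to compound 3 (1.66 log units; beyond the scatter), so the gap to the piperidin-1-yl group does not depend on a donor at this place. Compound 1 stands at a limit, not a number: the limit of > 50000 nM in this assay, at which 1 of the 3 values shown sits.

Going by these compounds, it remains open whether a smaller group such as dimethylamino, or a morpholine ring, would behave like cyclohexyl(methyl)amino at this place. On these data alone, a shorter or longer chain carrying the same amine is equally open.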